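A few compounds are considered here, and "the series" means these few. Any claim that something is new, unique, unknown or untested is made for them only; others in the source may bear on it.

Three compounds sharing one core have been measured in a functional assay on A-375 cells (Homo sapiens) for antiproliferative activity, read by MTT assay, with a stated time of 24 h; a lower number here means a stronger inhibitor, a higher number a weaker inhibitor:

Compound 1 `C=CCOc1ccc2c(=O)c(-c3cc(OC)c(OC)cc3OC)coc2c1`: 4750 nM
Compound 2 `COc1cc(OC)c(-c2coc3cc(OCc4ccccc4F)ccc3c2=O)cc1OC`: 2100 nM
Compound 3 `COc1cc(OC)c(-c2coc3cc(OCc4ccc(F)cc4)ccc3c2=O)cc1OC`: 1720 nM

Compound 1, which carries the allyloxy group, gives the highest number of the three in this assay. Replacing the vinyl with a 2-fluorophenyl gave a 2.3-fold lower number from compound 1 to compound 2 (0.35 log units; beyond the scatter), and with a 4-fluorophenyl gave a 2.8-fold lower number from compound 1 to compound 3 (0.44 log units; beyond the scatter); between the two fluorophenyl compounds the difference is a 1.2-fold lower number from compound 2 to compound 3 (0.09 log units; within the scatter), so the gain appears to come from the aryl ring itself rather than from where the fluorine sits.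

Compound 4 `COc1cc(OC)c(-c2coc3cc(OCc4ccc(C#N)cc4)ccc3c2=O)cc1OC` is not yet measured. It differs from compound 1 as follows: 4-cyanophenyl in place of vinyl on a saturated chain carbon bound to an oxygen on an aromatic ring. The two measured steps from compound 1 that bear on this change are the benzyl-type replacements of the vinyl, both modest and beyond the scatter and both in the direction of a lower number. A step of similar size is therefore expected for compound 4, in this assay, namely a 2.4-fold lower number from compound 1 to compound 4 (0.38 log units; beyond the scatter). Compound 4 is accordingly estimated to give 2000 nM, within a range from 1000 nM to 4000 nM.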

Compound 4, half-maximal inhibitory concentration: 1550 nM
The estimate for compound 4 lay 1.3-fold (0.11 log units) above the measured number; low and high end bracket the measured number.
By their numbers in this assay, from the lowest: compounds 4, 3 and 2 (each within the scatter of the next); then compound 1.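

Compound 4 extends the replacement of vinyl to an aryl ring carrying a nitrile instead of a fluorine, and the number again falls, with a 3.1-fold lower number from compound 1 to compound 4 (0.49 log units; beyond the scatter) in this assay. Cyano in place of fluoro on an aromatic carbon gives a 1.1-fold lower number from compound 3 to compound 4 (0.05 log units; within the scatter) and the change from 2-fluorophenyl to 4-cyanophenyl gives a 1.4-fold lower number from compound 2 to compound 4 (0.13 log units; within the scatter), so compounds 2, 3 and 4 remain within the scatter of one another, while each stands apart from compound 1. No measurement shown accounts for the lower numbers of these three compounds.

The compounds shown leave open whether a carboxylic acid or an amine in place of the cyano, or a plain phenyl in place of the vinyl, would give numbers in the same range. They also leave open how changes elsewhere on the shared core would read.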